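The compounds below may be only part of what the source reports. "The series", "measured", "known", "first", "only" and "open" are said of these compounds alone.

Measured compounds in an ADME assay on Huh-7 cells (Homo sapiens) for cytotoxicity, read by MTT assay, with a stated time of 48 h; a lower number here means that less compound is tolerated, a higher number that more compound is tolerated:
compound 1 `Nc1ccc(CN2N=C(c3ccc(F)cc3)C3C=CC=CC3C2=O)cc1` — > 80000 nM; this is a limit of the assay, not a number.
compound 2 `CN(C)CCCC(=O)Nc1ccc(CN2N=C(c3ccc(F)cc3)C3C=CC=CC3C2=O)cc1` — 38200 nM
compound 3 `CN(C)CCCCOC(=O)Nc1ccc(Cn2nc(-c3cnn(C)c3)c3ccccc3c2=O)cc1` — 55900 nM

Compound 3 gives the highest of the two numbers in this assay. The nearest number is that of compound 2, and the two lie within the scatter of each other, so no order between compound 3 and compound 2 can be read. Compound 1 sits at the limit of > 80000 nM in this assay, at which 1 of the 3 values shown sits, and its value is a limit only.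

Among the compounds with values here, the single measured step is an at least 2.0-fold lower number from compound 1 to compound 2 (0.32 log units; beyond the scatter), a change on the nitrogen attached to the aromatic ring. It does not touch the place that is altered between compound 3 and compound 4.

Compound 4 `COc1ccccc1-c1nn(Cc2ccc(NC(=O)OCCCCN(C)C)cc2)c(=O)c2ccccc12` differs from compound 3 by 2-methoxyphenyl in place of 1-methyl-1H-pyrazol-4-yl on an aromatic carbon. Within the data shown here, no measured step bears on this change: neither the aromatic group entering nor the one leaving is varied anywhere among the measured compounds, and the only step measured concerns a different part of the molecule. The expectation for this assay therefore rests on the standing of compound 3 alone, and the step from compound 3 to compound 4 is expected to be a 1.1-fold lower number from compound 3 to compound 4 (0.05 log units; within the scatter), that is, none beyond the scatter. On that basis compound 4 is estimated at 50000 nM in this assay, within the range 20000 nM to 90000 nM.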

Compound 4, half-maximal cytotoxic concentration: 44800 nM
Estimate against measurement, compound 4: 1.1-fold (0.05 log units) above, within the range that was stated.
By their numbers in this assay, from the lowest: compounds 2, 4 and 3 (each within the scatter of the next). At a limit, above all of these: compound 1.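

In this assay, within the data shown here, 2-methoxyphenyl in place of 1-methyl-1H-pyrazol-4-yl on the aromatic carbon next to the ring nitrogen gives a 1.2-fold lower number from compound 3 to compound 4 (0.10 log units; within the scatter), the first step at this position. Among these compounds, the earlier compounds supplied only a step on the nitrogen attached to the aromatic ring, so this is the first one-place reading here: a five-membered aromatic ring with 2 hetero atoms and a six-membered aromatic ring of carbon only cannot be told apart at this position in this cytotoxicity read-out, with the dimethylaminobutyl carbamate side chain held constant. The data at hand offer no explanation for this outcome.

Among the compounds shown here, the single exchange leaves open whether a plain phenyl, or a phenyl carrying a carboxylic acid or an amine in place of the methoxy group, would also stay within the scatter of compound 3 and compound 4. As far as these compounds go, it is also open whether the same exchange would read alike with a shorter or longer chain between the carbamate and the dimethylamino group, since the side chain does not vary between these two compounds.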